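The source may hold more compounds than are shown below. What is called first, only, known or untested is meant among the compounds shown, and "the series" means these compounds.

Measured so far:
- compound 1, `COc1ccc(-c2c(-c3ccc(OC)cc3)n(Cc3ccccc3)c3ncn([C@@H]4CCCC[C@H]4O)c(=N)c23)cc1`, gives 0.487 h
- compound 2, `COc1ccc(Cn2c(-c3ccccc3)c(-c3ccccc3)c3c(=N)n(CCCO)cnc32)cc1`, gives 0.332 h
- compound 3, `N=c1c2c(-c3ccccc3)c(-c3ccccc3)n(CC3CC3)c2ncn1C1CCOCC1`, gives 1.13 h

All three numbers come from an ADME assay on microsomes from liver (Mus musculus, strain CD1) for metabolic stability, read by LC-MS, using NADPH, with a stated time of 60 min; a higher number here means that the compound lasts longer, a lower number that the compound disappears faster. Among them compound 3 stands highest: its gap to compound 1, the nearest of the other two, lies beyond the usual scatter, and its gap to compound 2, the furthest, lies further beyond it still. No two of the measured compounds differ in a single place, so no single-change step can be read from these numbers; each pair differs in several places at once.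

Compound 4, `N=c1c2c(-c3ccccc3)c(-c3ccccc3)n(CC3CC3)c2ncn1CC1CCOCC1`, has not yet been measured in this assay. It differs from compound 3 in one place only: (oxan-4-yl)methyl in place of oxan-4-yl on an aromatic nitrogen. Within the data shown here, with no comparable single-change step among the measured compounds, the direction of this change cannot be read from the data; the account therefore expects a step from compound 3 to compound 4 of modest size, most likely within the usual scatter, a 1.3-fold lower number from compound 3 to compound 4 (0.10 log units; within the scatter). On that basis compound 4 is estimated to give 0.9 h, with a range from 0.45 h to 1.8 h, in this assay.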

Compound 4, half-life: 0.272 h
For compound 4 the middle estimate is 3.3-fold (0.52 log units) above the measured one; the whole stated range lies above it.
By their numbers in this assay, from the lowest: compounds 4, 2 and 1 (each within the scatter of the next); then compound 3.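

Among these compounds, this is the first single-change step in this assay, and it shows that this aromatic nitrogen is sensitive to a small change: (oxan-4-yl)methyl in place of oxan-4-yl gives a 4.2-fold lower number from compound 3 to compound 4 (0.62 log units; beyond the scatter). The six-membered non-aromatic ring, its one hetero atom and the counts of hydrogen-bond donors and acceptors all stay the same, while the heavy atoms of the group go from 6 to 7, so a minimal difference in these counts is enough to move the half-life beyond the scatter. Nothing available accounts for the size or direction of this step.

The compounds shown do not tell whether a longer chain carrying the same oxane ring would lower the number further, or whether a piperidine amine in place of the oxane ring would keep the number of compound 3. Nor do they tell whether the same change would give a step of similar size on the cores of compound 1 and compound 2, which carry other groups on this nitrogen.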